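A few compounds are considered here, and "the series" means these few. Any claim that something is new, unique, unknown or untested is made for them only; others in the source may bear on it.

Of the compounds shown here, two of this shared core have so far been tested in an assay on HEK293 cells for displacement of a labelled ligand from corticotropin-releasing factor receptor 1 (Homo sapiens), with a stated time of 2 h; a lower number here means a stronger inhibitor, a higher number a weaker inhibitor. Compound 1 `CCCN(CCC)c1ccc(C)c2nc(Oc3c(OC)cc(COC)cc3OC)c(C)cc12` returns only the limit of this assay, > 1000 nM, so no number is attached to it. Compound 2 `COCc1cc(OC)c(-c2nc3c(C)ccc(N(CC4CC4)CC4CC4)c3cc2C)c(OC)c1` gives 88 nM in this assay. Among the results shown, compound 2 therefore holds the only actual number; the other result is a limit, (the limit of > 1000 nM in this assay, at which 1 of the 2 values shown sits), so all that can be said is that compound 2 gave a number where compound 1 did not.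

Compound 3 `CCC(CC)Nc1ccc(C)c2nc(-c3c(OC)cc(COC)cc3OC)c(C)cc12` is the next compound to be tested. Its structure differs from compound 2 in one place: (pentan-3-yl)amino in place of bis(cyclopropylmethyl)amino on an aromatic carbon. Going by the values given here, no step between two measured compounds of this kind is available, so the effect of this change has to be judged from the change itself. Among the compounds with values here, with no such precedent, a step of modest size toward weaker binding is expected, though the outcome could also fall within the usual scatter. For compound 3 in this assay the estimate is 200 nM, expected to lie between 50 nM and 800 nM. That corresponds to an expected step of a 2.3-fold higher number from compound 2 to compound 3 (0.36 log units; beyond the scatter).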

Compound 3, half-maximal inhibitory concentration: > 1000 nM
Compound 3: a limit, no number; the forecaster's own chance of this, stated with the estimate: 15%; middle value at least 5.0-fold (0.69 log units) from the limit.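

In this assay, putting (pentan-3-yl)amino in place of bis(cyclopropylmethyl)amino on this aromatic carbon gives an at least 11-fold higher number from compound 2 to compound 3 (1.05 log units; beyond the scatter), so binding at this position clearly depends on which amino group it carries. The change alters several things at once: the entering group has 6 heavy atoms against 9, has no ring where the leaving group has 2 three-membered rings, and has 1 hydrogen-bond donor where the leaving group has none. The result for compound 3 is a limit, not a number: the limit of > 1000 nM in this assay, at which 2 of the 3 values shown sit.

Going by these compounds, whether the weaker binding goes with the lost rings, the smaller group or the hydrogen on the nitrogen remains open, since all three change together in this single step. A (cyclopropylmethyl)amino group, which keeps one ring and that hydrogen, or a methyl(pentan-3-yl)amino group, which keeps the open chain but has no such hydrogen, would begin to separate these features at this position.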